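The source may hold more compounds than are shown below. What is called first, only, known or untested is meant among the compounds shown, and "the series" means these compounds.

Measured so far:
- compound 1, `CCn1c(C(=O)NCC#N)ccc1C(CC)(CC)c1ccc(OCCC(O)(CC)CC)c(C)c1`, in an ADME assay on L02 cells (Homo sapiens) for antiproliferative activity, read by MTT assay, with a stated time of 48 h (on this read-out higher numbers stand for weaker inhibition and lower numbers for stronger inhibition), compound 1 gives > 50000 nM, which is a limit of this assay and not a number.
- compound 2, `C#CC(C)OC(=O)c1ccc(C(CC)(CC)c2ccc(OCCC(O)(CC)CC)c(C)c2)n1CC`, in this assay compound 2 gives > 50000 nM, again a limit and not a number.
- compound 3, `CCOC(=O)CN(C)C(=O)c1ccc(C(CC)(CC)c2ccc(OCCC(O)(CC)CC)c(C)c2)n1CC`, in this assay compound 3 gives 1990 nM.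

For the measured compounds named here, compound 3 is the only compound with a number; the other two values sit at a limit (the limit of > 50000 nM in this assay, at which 2 of the 3 values shown sit). The steps to it are large: an at least 25-fold lower number from compound 1 to compound 3 (1.40 log units; beyond the scatter) and an at least 25-fold lower number from compound 2 to compound 3 (1.40 log units; beyond the scatter), both beyond the scatter. The step from compound 1 to compound 2 cannot be read, since both ends are limits.

Compound 4, `CCn1c(C(=O)NC(C)CO)ccc1C(CC)(CC)c1ccc(OCCC(O)(CC)CC)c(C)c1`, differs from compound 3 at the carbonyl carbon: (1-(hydroxymethyl)ethyl)amino in place of ((ethoxycarbonyl)methyl)(methyl)amino on a carbonyl carbon. Both measured steps bear on this change, since each replaced a group on the same carbonyl carbon, and each moved the number by a large amount. Compound 4 again carries an amino group on the carbonyl, as compound 1 does, so the expectation is a rise back toward the limit. The estimated step for compound 4 is a 10-fold higher number from compound 3 to compound 4 (1.00 log units; beyond the scatter). Compound 4 is expected near 20000 nM, between 4000 nM and 60000 nM, with a real chance that only a limit is reported.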

Compound 4, half-maximal inhibitory concentration: 4840 nM
Compound 4: the middle estimate sits 4.1-fold (0.62 log units) above what was measured, within the range that was stated.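

At this carbonyl carbon, the group on an amide-type nitrogen is enough to separate a limit from a number in this assay: 1-(hydroxymethyl)ethyl in place of cyanomethyl gives an at least 10-fold lower number from compound 1 to compound 4 (1.01 log units; beyond the scatter). The ester-type (1-methylprop-2-yn-1-yl)oxy of compound 2 yields a similar gain when replaced by (1-(hydroxymethyl)ethyl)amino, with an at least 10-fold lower number from compound 2 to compound 4 (1.01 log units; beyond the scatter). A measurable number therefore does not depend on ((ethoxycarbonyl)methyl)(methyl)amino, although its replacement still costs a modest step, a 2.4-fold higher number from compound 3 to compound 4 (0.39 log units; beyond the scatter).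

As far as these compounds go, it remains open which part of (1-(hydroxymethyl)ethyl)amino carries the change, a question that a plain ethylamino group, a carboxylic acid or a longer hydroxyalkyl chain could address. The values of compound 1 and compound 2 are limits and not numbers, so the true sizes of their steps also stay open: the limit of > 50000 nM in this assay, at which 2 of the 4 values shown sit.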